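The source may report more compounds than this note shows. Statements on the series, on what has been measured and on what is new or still open speak of the compounds shown alone.

Working notes on the series. Three compounds have been run in an ADME assay on MDBK cells (Bos taurus) for cytotoxicity, read by MTT assay, with a stated time of 72 h; a lower number here means that less compound is tolerated, a higher number that more compound is tolerated: compound 1 `Cc1ccc(NCc2cn(-c3ccccc3)nc2-c2ccc(C(F)(F)F)cc2)cc1`, compound 2 `Cc1ccc(NCc2cn(-c3ccccc3)nc2-c2ccc(C)cc2)cc1` and compound 3 `Cc1ccc(NCc2cn(-c3ccccc3)nc2-c2ccccc2)cc1`. In this assay compound 1 gives > 100000 nM, which is a limit of the assay and not a number. Compound 2 gives > 100000 nM, also a limit. Compound 3 gives > 100000 nM, again a limit. All three sit at the limit of > 100000 nM in this assay, at which 3 of the 3 values shown sit, so the steps among them are not readable: a step that the two limits leave unreadable from compound 2 to compound 1, a step that the two limits leave unreadable from compound 1 to compound 3 and a step that the two limits leave unreadable from compound 2 to compound 3.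

Compound 4 `FC(F)(F)c1ccc(NCc2cn(-c3ccccc3)nc2-c2ccccc2)cc1` has not yet been measured in this assay. It differs from compound 3 by trifluoromethyl in place of methyl on an aromatic carbon. The same change, at the same place, is made from compound 2 to compound 1: trifluoromethyl in place of methyl on an aromatic carbon. The cores of compound 3 and compound 2 differ by hydrogen in place of methyl on an aromatic carbon.

For compound 4 the step that the limit leaves unreadable from compound 3 to compound 4 is expected to stay within the scatter, because the same change from compound 2 to compound 1 left compound 1 at the limit of > 100000 nM in this assay, at which 3 of the 3 values shown sit. Compound 4 is therefore estimated at 150000 nM, between 60000 nM and 500000 nM, most probably reported as a limit again.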

Compound 4, half-maximal cytotoxic concentration: 34000 nM
For compound 4 the middle estimate is 4.4-fold (0.64 log units) above the measured one, and the stated range ends above it.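

In this assay, trifluoromethyl in place of methyl, on an aromatic carbon para to a large group, gives an at least 2.9-fold lower number from compound 3 to compound 4 (0.46 log units; beyond the scatter), a readable drop in the number on this core. On the core of compound 2 the same change leads to compound 1, which gives > 100000 nM, a limit of the assay and not a number. This shows that the change can lower the number on one core, but it does not show that the size of the step carries over to another core or that the change does nothing there, and none of the steps among compound 1, compound 2 and compound 3 can be read: the limit of > 100000 nM in this assay, at which 3 of the 4 values shown sit.

The compounds shown carry only hydrogen, methyl or trifluoromethyl at the positions varied, so it stays open whether an amine, a carboxylic acid or a longer chain at the same place would also lower the number. As far as these compounds go, it also stays open how far below the limit any compound of this series would fall on the other cores.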